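A few compounds are considered here, and "the series" means these few. Any claim that something is new, unique, unknown or untested is made for them only; others in the source may bear on it.

Measured compounds:
- compound 1 `COc1cc2cc(Oc3ccc(NC(=O)Nc4cccc(C(F)(F)F)c4)cc3)c(C)nc2cc1OC`, which in a functional assay on MCF7 cells (Homo sapiens) for inhibition, read by sulforhodamine B assay, with a stated time of 48 h (on this read-out higher numbers stand for weaker inhibition of growth and lower numbers for stronger inhibition of growth), gives 1340 nM
- compound 2 `COc1cc2cc(Oc3ccc(NC(=O)Nc4ccc(Cl)c(C(F)(F)F)c4)cc3)c(C)nc2cc1OC`, which in this assay gives 1080 nM

Going by the values given here, compound 2 carries the smaller of the two numbers, but its only neighbour is compound 1, and the step of a 1.2-fold lower number from compound 1 to compound 2 (0.09 log units; within the scatter) lies within the scatter, so the two compounds cannot be told apart on these data.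

Compound 3 `COc1cc2cc(Oc3ccc(NC(=O)Nc4ccc(Cl)c(Cl)c4)cc3)c(C)nc2cc1OC` has not yet been measured. It differs from compound 2 in one place: chloro in place of trifluoromethyl on an aromatic carbon. Among the compounds with values here, no measured step swaps a trifluoromethyl for a chloro, so nothing bears directly on this change. Within the data shown here, the one step that is known, a 1.2-fold lower number from compound 1 to compound 2 (0.09 log units; within the scatter), touched the same ring and stayed within the scatter, which gives no sign that small changes on this ring move the number much. The expectation is therefore for a step no larger than the scatter, with no preferred direction, expressed as a 1.2-fold higher number from compound 2 to compound 3 (0.08 log units; within the scatter). On that basis compound 3 is estimated at 1300 nM, with a range from 500 nM to 3500 nM.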

Compound 3, concentration for 50% growth inhibition: 2890 nM
Compound 3: middle estimate off by 2.2-fold (0.35 log units), on the low side; the range from low to high includes it.
By their numbers in this assay, from the lowest: compounds 2 and 1 (each within the scatter of the next); then compound 3.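

In this assay the trifluoromethyl group on this aromatic carbon, ortho to a chloro group, proves not to be freely exchangeable: chloro in its place gives a 2.7-fold higher number from compound 2 to compound 3 (0.43 log units; beyond the scatter) and so leaves the scatter, if only modestly. Going by these compounds alone, this ring had looked insensitive so far, since the one earlier step, a 1.2-fold lower number from compound 1 to compound 2 (0.09 log units; within the scatter), stayed within the scatter, whereas 3,4-dichlorophenyl in place of 3-(trifluoromethyl)phenyl gives a 2.2-fold higher number from compound 1 to compound 3 (0.33 log units; beyond the scatter) and shows that growth inhibition does respond to what this ring carries, with trifluoromethyl the better of the two groups seen at this position next to nothing else tested there. No measurement at hand says what lies behind this step.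

With only trifluoromethyl and chloro shown at this position, the compounds leave open how a fluoro, a methyl, a methoxy, a nitrile or an amine would read there, and whether any of them would match trifluoromethyl or go beyond it. They also leave open whether the same exchange of trifluoromethyl for chloro gives a step of similar size when the chloro group of compound 2 is absent.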